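Shortening the alkyl chain on a shared nucleoside core

The source may report more compounds than this note shows. Statements on the series, on what has been measured and on what is new or still open speak of the compounds shown alone.

Compound 1 `CCCCCCCCCCCCCCCCNc1nc(=O)c2ncn([C@@H]3O[C@H](CO)[C@@H](O)[C@H]3O)c2c(=O)[nH]1` and compound 2 `CCCCCCCCCCCCCCCCCCNc1nc(=O)c2ncn([C@@H]3O[C@H](CO)[C@@H](O)[C@H]3O)c2c(=O)[nH]1` share one core and differ only in the length of a saturated chain. In an assay on isolated protein for inhibition of ATP-dependent RNA helicase SUPV3L1, mitochondrial (Homo sapiens) (on this read-out higher numbers stand for weaker inhibition and lower numbers for stronger inhibition), compound 1 gives 30 ug/mL and compound 2 gives 30 ug/mL. Among the compounds with values here, the one step between them, no change at the digits printed from compound 1 to compound 2 (within the scatter), shows that adding two chain carbons left the read-out where it was. Compound 2 therefore stands level with compound 1 on the numbers seen.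

Compound 3 `CCCCCCCCCCCCNc1nc(=O)c2ncn([C@@H]3O[C@H](CO)[C@@H](O)[C@H]3O)c2c(=O)[nH]1` differs from compound 2 by hydrogen in place of hexyl on a saturated chain carbon, ten or more bonds along the chain from a nitrogen on an aromatic ring. Within the data shown here, the only step available bears on it, as it also alters nothing but the length of that chain, and it was flat. Whether a larger cut behaves the same way is not known from these two compounds. The expected step in this assay is accordingly no change at the digits printed from compound 2 to compound 3 (within the scatter), none beyond the scatter. Compound 3 is estimated at 30 ug/mL, with a range from 12 ug/mL to 75 ug/mL.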

Compound 3, half-maximal inhibitory concentration: 150 ug/mL
Compound 3: the middle estimate sits 5.0-fold (0.70 log units) below what was measured; the whole stated range lies below it.
By their numbers in this assay, from the lowest: compounds 1 and 2 (each within the scatter of the next); then compound 3.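

In this assay, the length of the chain at this place is not indifferent after all: cutting hexyl back to hydrogen gives a 5.0-fold higher number from compound 2 to compound 3 (0.70 log units; beyond the scatter), and the shorter cut of butyl to hydrogen gives a 5.0-fold higher number from compound 1 to compound 3 (0.70 log units; beyond the scatter). The flat step between compounds 1 and 2 therefore holds only for the two longest chains here, and compound 3, with the shortest chain of the three, is the weakest inhibitor of the set. No measurement offered here explains this loss of inhibition.

The three compounds do not locate where between the chains of compound 3 and compound 1 the rise begins, or whether it continues with a still shorter chain. Nor do they tell how a chain ending in a carboxylic acid or an amine would read at this place.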